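This account rests on a few compounds, and the source may have more. Where it says the series, first, only, none or still open, it means among the compounds named here.

Series built on the shared core of compound 1 `COc1ccc(CN(C(=O)COc2ccc(OC)cc2)c2cc(OC)c(OC)c(OC)c2)cc1`, with variation in the group on a saturated chain carbon bound to a carbonyl carbon. In a functional assay on PC-3 cells (Homo sapiens) for antiproliferative activity, read by MTT assay, with a stated time of 48 h (a higher number here means a weaker inhibitor, a lower number a stronger inhibitor), compound 1 gives 66400 nM. Compound 2 `COc1ccc(CN(C(=O)CSc2ccccn2)c2cc(OC)c(OC)c(OC)c2)cc1` gives 7510 nM in this assay, an 8.8-fold lower number from compound 1 to compound 2 (0.95 log units; beyond the scatter). Compound 3 `COc1ccc(CN(C(=O)COc2cccc(Cl)c2)c2cc(OC)c(OC)c(OC)c2)cc1` gives 30500 nM in this assay, a 2.2-fold lower number from compound 1 to compound 3 (0.34 log units; beyond the scatter), and a 4.1-fold higher number from compound 2 to compound 3 (0.61 log units; beyond the scatter). Compound 3 thus stands second highest of the three numbers, nearest to compound 1 and furthest from compound 2.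

Compound 4 `COc1ccc(CN(C(=O)COc2cc(OC)c(OC)c(OC)c2)c2cc(OC)c(OC)c(OC)c2)cc1` differs from compound 3 in one place: 3,4,5-trimethoxyphenyl in place of 3-chlorophenyl on an oxygen on a saturated carbon. Going by the values given here, the only measured step that touches the group on this oxygen is a 2.2-fold lower number from compound 1 to compound 3 (0.34 log units; beyond the scatter), where 4-methoxyphenyl gave way to 3-chlorophenyl. Among the compounds with values here, compound 4 moves back to a methoxy-bearing ring and carries three such groups instead of one; for the added groups no measured pair exists, so the range is set wide. A modest rise in this assay is therefore expected, roughly reversing that earlier step. Compound 4 is expected to give 60000 nM in this assay, within 20000 nM to 150000 nM, which means a 2.0-fold higher number from compound 3 to compound 4 (0.29 log units; within the scatter).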

Compound 4, half-maximal inhibitory concentration: > 80000 nM
Compound 4: a limit, no number; the forecaster's own chance of this, stated with the estimate: 15%; middle value at least 1.3-fold (0.12 log units) from the limit.
By their numbers in this assay, from the lowest: compound 2; then compound 3; then compound 1. At a limit, above all of these: compound 4.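

Compound 4 gives a limit and not a number in this assay: the limit of > 80000 nM in this assay, at which 1 of the 4 values shown sits.

At the group on an oxygen on a saturated carbon, the series now moves in both directions: 3-chlorophenyl gave a lower number than 4-methoxyphenyl in a 2.2-fold lower number from compound 1 to compound 3 (0.34 log units; beyond the scatter), while 3,4,5-trimethoxyphenyl in place of 3-chlorophenyl gives an at least 2.6-fold higher number from compound 3 to compound 4 (0.41 log units; beyond the scatter). Going by these compounds alone, the exchange of 3-chlorophenyl for 3,4,5-trimethoxyphenyl is thus the first step at this position to be read as unfavourable, though the data give no reason for it. Against the single methoxy ring, the result is an at least 1.2-fold higher number from compound 1 to compound 4 (0.08 log units; that floor lies within the scatter) and no order can be claimed between the 4-methoxyphenyl and 3,4,5-trimethoxyphenyl groups.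

The lowest number still belongs to the (pyridin-2-yl)sulfanyl group, seen in an 8.8-fold lower number from compound 1 to compound 2 (0.95 log units; beyond the scatter), and that step changes the ring and the linking atom together, so a phenylsulfanyl group or a pyridin-2-yloxy group on the same saturated chain carbon would be needed to separate the two. Also open, as far as these compounds go, is how a ring carrying an amine or a carboxylic acid would read on this oxygen.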